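This account rests on a few compounds, and the source may have more. Where it says the series, first, only, none or still open, it means among the compounds named here.

Measured so far:
compound 1, `COc1cc(C(=O)N2CCC(C)(C)C2)cc2nc(NCc3cccc(Cl)c3)oc12`: 40 nM in an assay on isolated protein for inhibition of thyroid hormone receptor beta (Homo sapiens), read by fluorescence, with a stated time of 30 min; a higher number here means a weaker inhibitor, a lower number a stronger inhibitor
compound 2, `COc1cc(C(=O)N2CC[C@@H](O)[C@H](C)C2)cc2nc(NCc3cccc(Cl)c3)oc12`: 10 nM in this assay
compound 3, `COc1cc(C(=O)N2CCC(O)C(C)C2)cc2nc(NCc3ccnc(Cl)c3)oc12`: 6900 nM in this assay

Compound 3 stands highest of the three numbers and is the weakest inhibitor of the set; compound 1 lies nearer to it and compound 2 furthest, both gaps well beyond the scatter. Within the data shown here, the only single-point step recorded runs from compound 1 to compound 2, a 4.0-fold lower number from compound 1 to compound 2 (0.60 log units; beyond the scatter), an exchange on the carbonyl carbon that leaves the aromatic amine side untouched. Among the measured compounds shown here, compound 3 differs from compound 2 in more than one place, so the values of compound 2 and compound 3 show only that the chloropyridinyl compound sits far higher.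

Compound 4, `COc1cc(C(=O)N2CCC(O)C(C)C2)cc2nc(N[C@@H](C)c3cccc(Cl)c3)oc12`, carries 1-(3-chlorophenyl)ethyl in place of (2-chloropyridin-4-yl)methyl on a nitrogen on an aromatic ring. This returns the chlorophenyl ring shared by compound 1 and compound 2, with an added methyl branch as the name 1-(3-chlorophenyl)ethyl tells. For the measured compounds named here, no measured step covers this exchange directly. The one bearing is the large gap between compound 3 and the chlorophenyl pair. A large decrease is therefore expected in this assay, a 170-fold lower number from compound 3 to compound 4 (2.24 log units; beyond the scatter). Going by the values given here, the methyl branch has no measured precedent, and the expectation is set short of compound 1. Compound 4 is estimated at 40 nM, with a range of 8 nM to 250 nM.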

Compound 4, half-maximal inhibitory concentration: 5100 nM
Compound 4: middle estimate off by 130-fold (2.11 log units), on the low side, and the stated range ends below it.
By their numbers in this assay, from the lowest: compound 2; then compound 1; then compounds 4 and 3 (each within the scatter of the next).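

In this assay the exchange on the nitrogen reads as a 1.4-fold lower number from compound 3 to compound 4 (0.13 log units; within the scatter) and so does not separate the (2-chloropyridin-4-yl)methyl and 1-(3-chlorophenyl)ethyl groups; a chlorophenyl ring at this position does not by itself go with the low numbers of compound 1 and compound 2. Compound 2, with its unbranched chlorophenyl group, stands at 10 nM and compound 4 at 5100 nM in the same assay, but the two also differ in the stereochemistry printed on the piperidine, so these values do not isolate the methyl branch. No supporting data bear on why this exchange leaves the value within the scatter.

The step from compound 3 to compound 4 bundles the loss of the ring nitrogen, the new methyl branch and the relocated chlorine, and these cannot be read apart from the compounds shown. A 1-(2-chloropyridin-4-yl)ethyl group or a (3-chlorophenyl)methyl group on the same hydroxy-methylpiperidine amide would bear on this, as would the opposite configuration of the 1-(3-chlorophenyl)ethyl group.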